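The source may hold more compounds than are shown below. What is called first, only, known or untested is meant among the compounds shown, and "the series" means these compounds.

Measured in a functional assay on CCRF-CEM cells (Homo sapiens) for antiproliferative activity, with a stated time of 72 h; a lower number here means a stronger inhibitor, a higher number a weaker inhibitor:
compound 1 `OC[C@H]1O[C@@H](n2cnc3c(NCc4cccc(F)c4)ncnc32)[C@H](O)[C@@H]1O` gives 4000 nM
compound 2 `OC[C@H]1O[C@@H](n2cnc3c(NCc4ccccc4Cl)ncnc32)[C@H](O)[C@@H]1O` gives 14500 nM
compound 3 `OC[C@H]1O[C@@H](n2cnc3c(NCc4ccc(Cl)cc4)ncnc32)[C@H](O)[C@@H]1O` gives 10200 nM

Compound 2 sits with compound 3 at the high-number end of this small set, and a 1.4-fold lower number from compound 2 to compound 3 (0.15 log units; within the scatter) leaves the two unseparated. Compound 1 stands apart from both: a 3.6-fold higher number from compound 1 to compound 2 (0.56 log units; beyond the scatter) and a 2.6-fold higher number from compound 1 to compound 3 (0.41 log units; beyond the scatter) are modest but beyond the scatter.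

Next in line is compound 4 `Cc1cccc(CNc2ncnc3c2ncn3[C@@H]2O[C@H](CO)[C@@H](O)[C@H]2O)c1`, which keeps the shared core and changes only the aryl group. The difference is 3-methylphenyl in place of 2-chlorophenyl on a saturated chain carbon bound to a nitrogen on an aromatic ring. Among the measured compounds shown here, no measured compound carries a methyl group, so the evidence is indirect. For the measured compounds named here, the nearest guide is compound 1, the only measured compound with its substituent named at the 3 position of the phenyl group, and a 3.6-fold higher number from compound 1 to compound 2 (0.56 log units; beyond the scatter) runs in the opposite direction to the change now in view. This rests on a single compound, so only part of that step is carried over, and a lower number than for compound 2 is expected in this assay. The expected step is modest, and it may not clear the scatter: a 2.2-fold lower number from compound 2 to compound 4 (0.35 log units; beyond the scatter) is the estimate. For compound 4 the estimated value is 6500 nM, with an expected range of 2800 nM to 14000 nM.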

Compound 4, half-maximal inhibitory concentration: 19100 nM
Compound 4: the middle estimate sits 2.9-fold (0.47 log units) below what was measured, and the stated range ends below it.
By their numbers in this assay, from the lowest: compound 1; then compounds 3, 2 and 4 (each within the scatter of the next).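

Position alone does not account for the low number of compound 1: the 3-methylphenyl group of compound 4 shares the named position with the 3-fluorophenyl group, yet the exchange of fluoro for methyl on that aromatic carbon gives a clear loss (a 4.8-fold higher number from compound 1 to compound 4 (0.68 log units; beyond the scatter)). Compound 4 instead falls in with the two chlorophenyl compounds (a 1.3-fold higher number from compound 2 to compound 4 (0.12 log units; within the scatter); a 1.9-fold higher number from compound 3 to compound 4 (0.27 log units; within the scatter)), so 3-methylphenyl cannot be separated from either 2-chlorophenyl or 4-chlorophenyl on this saturated chain carbon. Among the four compounds, only compound 1 stands apart, and the separation now rests on its single fluoro-bearing group rather than on a substituent at the 3 position in general, while no measurement at hand explains the gap between fluoro and methyl.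

Still open, on these data alone, is whether 3-chlorophenyl or 3-methoxyphenyl would fall with compound 1 or with compound 4, and whether 2-fluorophenyl or 4-fluorophenyl would keep the number of compound 1. Also open, as far as these compounds go, is how an amine or a carboxylic acid on the phenyl group, or a longer chain in place of the benzyl link, would read.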